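Sulfonamide aryl variation on a shared core

The compounds below may be only part of what the source reports. "The series", "measured", "known", "first", "only" and "open" are said of these compounds alone.

The shared core carries a sulfonamide whose aryl group is varied. Compound 1 `COc1cc2c(Oc3ccc(NS(=O)(=O)c4ccccc4C(F)(F)F)cc3F)ccnc2cc1OCCCN1CCN(C)CC1`, with a 2-(trifluoromethyl)phenyl on the sulfonyl sulfur, gives 21 nM in an assay on isolated protein for inhibition of tyrosine-protein kinase receptor UFO (Homo sapiens); a lower number here means a stronger inhibitor, a higher number a weaker inhibitor. Compound 2 `COc1cc2c(Oc3ccc(NS(=O)(=O)c4ccccc4OC(F)(F)F)cc3F)ccnc2cc1OCCCN1CCN(C)CC1`, with a 2-(trifluoromethoxy)phenyl in the same place, gives 51 nM in this assay and so holds the highest number of the three measured compounds. Compound 3 `COc1cc2c(Oc3ccc(NS(=O)(=O)c4cc(F)ccc4F)cc3F)ccnc2cc1OCCCN1CCN(C)CC1`, with a 2,5-difluorophenyl on the sulfonyl sulfur, gives 27 nM in this assay. The step of a 2.4-fold higher number from compound 1 to compound 2 (0.39 log units; beyond the scatter) is beyond the scatter, whereas the steps of a 1.3-fold higher number from compound 1 to compound 3 (0.11 log units; within the scatter) and a 1.9-fold lower number from compound 2 to compound 3 (0.28 log units; within the scatter) stay within it.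

Compound 4 `COc1cc2c(Oc3ccc(NS(=O)(=O)c4c(F)cccc4F)cc3F)ccnc2cc1OCCCN1CCN(C)CC1` has not been measured. Its change from compound 2 is 2,6-difluorophenyl in place of 2-(trifluoromethoxy)phenyl on a sulfonyl sulfur. The step that bears most directly on it is a 1.9-fold lower number from compound 2 to compound 3 (0.28 log units; within the scatter), where a different difluorophenyl replaced the same 2-(trifluoromethoxy)phenyl and compound 3 came out within the scatter of compound 2; the step of a 1.3-fold higher number from compound 1 to compound 3 (0.11 log units; within the scatter) likewise places the difluorophenyl and trifluoromethyl analogues close together. A small move to a lower number, at most around the edge of the scatter, is therefore expected, and the step of a 1.7-fold lower number from compound 2 to compound 4 (0.23 log units; within the scatter) is the estimate. Compound 4 is expected to give 30 nM in this assay, within a range from 12 nM to 75 nM.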

Compound 4, half-maximal inhibitory concentration: 35 nM
Compound 4: the middle estimate sits 1.2-fold (0.07 log units) below what was measured; the measured number falls inside the stated range.
By their numbers in this assay, from the lowest: compounds 1, 3, 4 and 2 (each within the scatter of the next, the first and the last beyond it).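

Two difluorophenyl groups on the sulfonyl sulfur can now be compared, and a 1.3-fold higher number from compound 3 to compound 4 (0.11 log units; within the scatter) shows no separation between the 2,5-difluorophenyl and the 2,6-difluorophenyl in this assay. The 2,6-difluorophenyl also stays within the scatter of both the 2-(trifluoromethoxy)phenyl, with a 1.5-fold lower number from compound 2 to compound 4 (0.16 log units; within the scatter) as the step, and the 2-(trifluoromethyl)phenyl, with a 1.7-fold higher number from compound 1 to compound 4 (0.22 log units; within the scatter) as the step. Within the data shown here, compound 4 therefore adds no further separation at this position: the only step outside the scatter among the four compounds is still a 2.4-fold higher number from compound 1 to compound 2 (0.39 log units; beyond the scatter) in this series.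

Every group shown on the sulfonyl sulfur is a fluorine-bearing phenyl, so it stays open whether an unsubstituted phenyl, a phenyl carrying an amine or a carboxylic acid, or a longer alkyl chain in the same place would stay within this narrow band of values. No supporting measurement is available to explain the closeness of these four compounds.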